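Trimming the Ether Side Chain of an Agonist Series

A few compounds are considered here, and "the series" means these few. Any claim that something is new, unique, unknown or untested is made for them only; others in the source may bear on it.

Three compounds have been measured in a functional assay on HEK293 cells for agonist activity at G-protein coupled receptor 39 (Homo sapiens), read by scintillation proximity assay and inositol phosphate accumulation, with a stated time of 75 min; a lower number here means that less compound is needed, a higher number that more compound is needed for the effect:

Compound 1 `Cc1nn(-c2ncnc3nc[nH]c23)c2c1C(OCc1cc(F)cc3c1OCOC3)CC(=O)N2`: 30 nM
Compound 2 `CCC(C(=O)NC1CC(=O)Nc2c1c(C)nn2-c1ncnc2nc[nH]c12)c1ccccc1`: 79 nM
Compound 3 `Cc1cc(C)nc(-n2nc(C)c3c2NC(=O)CC3c2ccc(COc3cccc(Cl)c3)cc2)n1`: 3000 nM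

Compound 1 holds the lowest number of the three. Compound 2 sits nearest to it, with a number that is larger by an amount beyond the usual scatter, and compound 3 lies far away, with a number larger by a wide margin. All three share the same bicyclic lactam core, and they differ in the group attached to the saturated carbon of that core and in the heteroaryl ring on the nitrogen.

Compound 4 `COc1ccc(CCOC2CC(=O)Nc3c2c(C)nn3-c2ncnc3nc[nH]c23)cc1` is not yet measured. It keeps the core and the heteroaryl ring of compound 1 and alters only the ether side chain: a group of 9 heavy atoms (8 carbon, 1 oxygen; one six-membered aromatic ring of carbon only) in place of a group of 11 heavy atoms (8 carbon, 2 oxygen, 1 fluorine; one six-membered non-aromatic ring with 2 hetero atoms, one six-membered aromatic ring of carbon only), on a saturated chain carbon bound to an oxygen on a saturated carbon. The group that enters is smaller and carries one hydrogen-bond acceptor instead of two, and it lacks the fluorine.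

Going by the values given here, no pair of measured compounds differs in one place only, so there is no directly comparable step. The expectation for the step of a 5.0-fold higher number from compound 1 to compound 4 (0.70 log units; beyond the scatter) in this assay is a moderate rise in the number, beyond the scatter but well short of the gap to compound 3. Compound 4 is therefore estimated at 150 nM, within a range from 40 nM to 600 nM.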

Compound 4, half-maximal effective concentration: 70 nM
Compound 4: middle estimate off by 2.1-fold (0.33 log units), on the high side; the measured number falls inside the stated range.
By their numbers in this assay, from the lowest: compound 1; then compounds 4 and 2 (each within the scatter of the next); then compound 3.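

Swapping the larger ether group for 4-methoxybenzyl, on a saturated chain carbon bound to an oxygen on a saturated carbon, gives in this assay a 2.3-fold higher number from compound 1 to compound 4 (0.37 log units; beyond the scatter). Going by these compounds alone, this is the only comparison here in which the shared core and the heteroaryl ring stay fixed, so it isolates this one side chain, and the modest size of the step shows that the fluorine and the six-membered non-aromatic ring can both be removed without a large loss, even though the number does rise. Nothing measured here explains why the number moves in this direction or by this amount.

Because the step removes the fluorine, the non-aromatic ring and a hydrogen-bond acceptor all at once, it cannot show how much each of them contributes to the rise. The compounds shown also leave open how the number would respond to a plain benzyl group without the methoxy, to a fluorine placed on the 4-methoxybenzyl group, or to an amine or a carboxylic acid at the end of this side chain.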